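A Nitrile Analog Tested for Macrophage Cytotoxicity

The compounds below may be only part of what the source reports. "The series", "measured", "known", "first", "only" and "open" are said of these compounds alone.

Compound 1 `CCCCOc1ccc(C(O)C2OC(=O)c3c(OC)cc(OC)cc32)cc1`: > 40000 nM
Compound 2 `COCCOc1ccc(C(O)C2OC(=O)c3c(OC)cc(OC)cc32)cc1`: > 40000 nM
Compound 3 `COc1cc(OC)c2c(c1)C(C(O)c1ccc(OCc3ccc(Cl)cc3)cc1)OC2=O`: > 40000 nM

The three measured compounds share one core and differ only in the group on a saturated chain carbon bound to an oxygen on an aromatic ring. In an ADME assay on RAW264.7 cells (Mus musculus) for cytotoxicity, read by MTT assay, with a stated time of 24 h, in the absence of a further agent (a higher number here means a weaker inhibitor, a lower number a stronger inhibitor), compound 1 gives > 40000 nM, which is a limit of the assay and not a number. Compound 2 gives > 40000 nM, also a limit. Compound 3 gives > 40000 nM, again a limit. Because (the limit of > 40000 nM in this assay, at which 3 of the 3 values shown sit), compound 1 stands at the same limit as the other two, and no order among them can be read.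

Compound 4 `COc1cc(OC)c2c(c1)C(C(O)c1ccc(OCc3ccc(C#N)cc3)cc1)OC2=O` differs from compound 1 by 4-cyanophenyl in place of propyl on a saturated chain carbon bound to an oxygen on an aromatic ring. The nearest measured step is a step that the two limits leave unreadable from compound 1 to compound 3, where 4-chlorophenyl took the place of propyl at the same position; a step that the two limits leave unreadable from compound 1 to compound 2 and a step that the two limits leave unreadable from compound 2 to compound 3 are equally unreadable. Within the data shown here, no size of step in this assay can be drawn from these, and the most likely outcome is that compound 4 also falls at the limit. Compound 4 is therefore estimated at 50000 nM, with a range from 20000 nM to 200000 nM. The expected step is a step that the limit leaves unreadable from compound 1 to compound 4, which is an estimate only.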

Compound 4, half-maximal inhibitory concentration: > 40000 nM
Compound 4: a limit, no number (the forecaster's own chance of this, stated with the estimate: 85%); the middle value is on the limit's open side.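

Compound 4 stands at the same limit of the assay as compound 1, compound 2 and compound 3, so none of its steps to them can be read and no order among the four can be drawn: the limit of > 40000 nM in this assay, at which 4 of the 4 values shown sit. The compounds shown leave open how far apart these four really lie in this assay, since none gives an actual number.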